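A few compounds are considered here, and "the series" means these few. Any claim that something is new, unique, unknown or untested is made for them only; others in the source may bear on it.

Compound 2 `O=C(NO)c1ccc(NCc2nc(-c3ccccc3)nn2-c2ccc(F)cc2)cc1` has the higher of the two numbers recorded so far: in an assay on Sf9 cells for inhibition of protein deacetylase HDAC6 (Homo sapiens), read by fluorescence, with a stated time of 40 min (a lower number here means a stronger inhibitor, a higher number a weaker inhibitor), compound 2 gives 274 nM, while compound 1 `COc1ccc(-n2nc(-c3ccccc3)nc2CNc2ccc(C(=O)NO)cc2)cc1` gives 127 nM in this assay. Going by the values given here, the single known step, a 2.2-fold higher number from compound 1 to compound 2 (0.33 log units; beyond the scatter), comes from fluoro in place of methoxy on an aromatic carbon. Among the compounds with values here, compound 3 `Cc1cccc(-n2nc(-c3ccccc3)nc2CNc2ccc(C(=O)NO)cc2)c1` differs from compound 2 by 3-methylphenyl in place of 4-fluorophenyl on an aromatic nitrogen; it has no measurement yet. The known step touches the same group that sits on an aromatic nitrogen of the five-membered ring, so it bears on this change, but only loosely, since the replaced group and the new group are both different here. That step was modest, and nothing in the data points firmly in one direction. A step of similar size or smaller is expected, a 1.4-fold lower number from compound 2 to compound 3 (0.14 log units; within the scatter), with the direction open. Compound 3 is estimated at 200 nM, within 70 nM to 550 nM.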

Compound 3, half-maximal inhibitory concentration: 388 nM
The estimate for compound 3 lay 1.9-fold (0.29 log units) below the measured number; the measured number falls inside the stated range.
By their numbers in this assay, from the lowest: compound 1; then compounds 2 and 3 (each within the scatter of the next).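

In this assay, replacing 4-fluorophenyl with 3-methylphenyl on the aromatic nitrogen gives a 1.4-fold higher number from compound 2 to compound 3 (0.15 log units; within the scatter) and so does not separate these two groups, even though one carries fluorine and the other a methyl group at a different ring position. Replacing 4-methoxyphenyl with 3-methylphenyl gives a 3.1-fold higher number from compound 1 to compound 3 (0.49 log units; beyond the scatter), which leaves compound 1 as the most potent of the three, with the lowest number by a margin beyond the scatter. No measurement here explains why the 4-methoxyphenyl group gives the lowest number.

The compounds shown cannot separate the identity of the ring substituent from its position, and a 3-methoxyphenyl group would address that directly. On these data alone, how an amine on this ring, as in 4-aminophenyl, or an unsubstituted phenyl on this nitrogen would compare also remains open.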